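A Sulfur Substituent on the Five-Membered Ring

A few compounds are considered here, and "the series" means these few. Any claim that something is new, unique, unknown or untested is made for them only; others in the source may bear on it.

Measured so far:
Compound 1, `CC(C)(C)c1nc2c(OCc3ccccc3)cccn2c1N`: 2%
Compound 2, `CC(=O)Nc1c(C)nc2c(CCc3ccccc3)cccn12`: 3%
Compound 3, `CCNc1c(C)nc2c(CCc3ccccc3)cccn12`: 11%

All three compounds were tested in a functional assay on the whole organism with Canis familiaris (Canis lupus familiaris) as the target, at a dose of 5 mg/kg by the intravenous route; a higher number here means a stronger effect of the compound at the dose given, a lower number a weaker effect. In this assay compound 3 gives the highest of the three numbers, but its gaps to compound 2 and to compound 1 both lie within the scatter, so none of the three can be called stronger or weaker than another.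

Compound 4, `CSc1c(C)nc2c(CCc3ccccc3)cccn12`, has not yet been measured. It differs from compound 3 in one place: methylsulfanyl in place of ethylamino on an aromatic carbon.

Among the compounds with values here, only one measured step exists, and it changed the group at the same aromatic carbon: a number 8 percentage points higher from compound 2 to compound 3 (within the scatter). That swap of one nitrogen-bound group for another produced no change beyond the scatter. Within the data shown here, no measured step tells what a methylsulfanyl group does at this position, so the expectation rests on that single step and on the low numbers of all three compounds.

On this basis the step is expected to be small, a number 4 percentage points lower from compound 3 to compound 4 (within the scatter), with no direction beyond the scatter. Compound 4 is therefore estimated to give 7%, in a range from 0% to 20%.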

Compound 4, a percentage reported as inhibition, in the whole organism at one dose (the size of the read-out at that dose, not a potency): 0%
Compound 4: middle estimate off by 7 percentage points, on the high side; low and high end bracket the measured number.
By their numbers in this assay, from the lowest: compounds 4, 1, 2 and 3 (each within the scatter of the next, the first and the last beyond it).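

In this assay, the change at this aromatic carbon gives its first step beyond the scatter, a number 11 percentage points lower from compound 3 to compound 4 (beyond the scatter), whereas the earlier swap of acetamido for ethylamino, a number 8 percentage points higher from compound 2 to compound 3 (within the scatter), did not. The result therefore shows that this position does not accept every replacement equally: methylsulfanyl, which has no hydrogen-bond donor, can be told apart from ethylamino, which has one, although the step is modest. Acetamido stays unresolved from both groups, since a number 3 percentage points lower from compound 2 to compound 4 (within the scatter) also lies within the scatter, and no measurement shown here explains the drop from ethylamino to methylsulfanyl.

On these data alone, it remains open whether the nitrogen, the hydrogen-bond donor or some other difference matters most, and methoxy, ethylsulfanyl or propylamino on the same carbon could help separate these possibilities. Since compound 3 itself reaches only 11% at the single dose shown, it is also unclear whether the separation between ethylamino and methylsulfanyl would hold at other doses.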